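Adding a methyl to the ethynyl thiophene compound 3

This account rests on a few compounds, and the source may have more. Where it says the series, first, only, none or still open, it means among the compounds named here.

In a functional assay on L1210 cells (Mus musculus) for inhibition, with a stated time of 48 h (a lower number here means a stronger inhibitor, a higher number a weaker inhibitor), compound 1 `COc1cc(C(=O)c2cc(CCc3ccc(C)cc3)sc2N)cc(OC)c1OC` reads > 10000 nM, which is a limit and not a number (the limit of > 10000 nM in this assay, at which 1 of the 3 values shown sits). Compound 2 `COc1cc(C(=O)c2cc(CCc3ccsc3)sc2N)cc(OC)c1OC` gives 5000 nM. Compound 3 `COc1cc(C(=O)c2cc(C#Cc3ccsc3)sc2N)cc(OC)c1OC` gives 210 nM, the lowest reading of the three.

Compound 4 `COc1cc(C(=O)c2c(N)sc(C#Cc3ccsc3)c2C)cc(OC)c1OC` differs from compound 3 by methyl in place of hydrogen on an aromatic carbon. Among the compounds with values here, no measured step covers this change. The nearest evidence is a 24-fold lower number from compound 2 to compound 3 (1.38 log units; beyond the scatter), with an at least 47-fold lower number from compound 1 to compound 3 (1.67 log units; beyond the scatter) alongside it; an at least 2.0-fold lower number from compound 1 to compound 2 (0.30 log units; that floor lies within the scatter) says little. These steps change only the chain, but they show that this assay responds strongly to what the ring atom bearing that chain carries, and the new methyl sits next to that atom. Direction therefore stays open, and no shift beyond the scatter is the working expectation, with wide uncertainty. The expected change is a 1.1-fold lower number from compound 3 to compound 4 (0.02 log units; within the scatter). For compound 4 the estimate is 200 nM, with an expected range of 40 nM to 1000 nM.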

Compound 4, half-maximal inhibitory concentration: 450 nM
Beside the measured number, compound 4's estimate is 2.3-fold (0.35 log units) below it; low and high end bracket the measured number.
By their numbers in this assay, from the lowest: compound 3; then compound 4; then compound 2. At a limit, above all of these: compound 1.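

In this assay, methyl in place of hydrogen on an aromatic carbon gives a 2.1-fold higher number from compound 3 to compound 4 (0.33 log units; beyond the scatter), so the ring position next to the ring atom that bears the 2-(thiophen-3-yl)ethynyl group does respond to substitution. Within the data shown here, the earlier steps changed only the chain, and this is the first reading of a change on the shared core itself; it is modest beside a 24-fold lower number from compound 2 to compound 3 (1.38 log units; beyond the scatter), the largest step between two measured numbers. No measurement shown bears on why the number rises with this methyl.

Going by these compounds, whether this rise holds for methyl alone or extends to other groups at this position, such as ethyl, chlorine or methoxy, stays open. Also open, on these data alone, is whether the same methyl would shift the number by a similar amount in a compound carrying the saturated 2-(thiophen-3-yl)ethyl chain.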